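Aryl variation on the ring nitrogen: compounds 1 to 4

The source may hold more compounds than are shown below. What is called first, only, known or untested is meant among the compounds shown, and "the series" means these compounds.

Measured so far:
compound 1, `COc1ccc(/C=C\C(=O)O)c(OCc2cn(-c3ccc(NC(=O)c4ccccc4)cc3)nn2)c1CC=C(C)C`, gives 21200 nM in a functional assay on A-431 cells (Homo sapiens) for cytotoxicity, read by MTT assay, with a stated time of 24 h; on this read-out lower numbers stand for stronger inhibition and higher numbers for weaker inhibition;
compound 2, `COc1ccc(/C=C\C(=O)O)c(OCc2cn(-c3cccc(C#N)c3)nn2)c1CC=C(C)C`, gives 22900 nM in this assay;
compound 3, `COc1ccc(/C=C\C(=O)O)c(OCc2cn(-c3ccc(CO)cc3)nn2)c1CC=C(C)C`, gives 16400 nM in this assay.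

Compound 3 shows the lowest of the three numbers, but the separation is slight: a 1.3-fold lower number from compound 1 to compound 3 (0.11 log units; within the scatter) and a 1.4-fold lower number from compound 2 to compound 3 (0.14 log units; within the scatter) both sit within the scatter, so the three read as one level.

Compound 4, `COc1ccc(/C=C\C(=O)O)c(OCc2cn(-c3ccccc3C#N)nn2)c1CC=C(C)C`, differs from compound 3 by 2-cyanophenyl in place of 4-(hydroxymethyl)phenyl on an aromatic nitrogen. The step that bears on it most directly is a 1.4-fold lower number from compound 2 to compound 3 (0.14 log units; within the scatter), a nitrile-for-hydroxymethyl swap on the same aryl group that moved nothing beyond the scatter; a 1.3-fold lower number from compound 1 to compound 3 (0.11 log units; within the scatter) points the same way. For compound 4 in this assay a step of a 1.2-fold higher number from compound 3 to compound 4 (0.06 log units; within the scatter) is therefore expected, nothing beyond the scatter. The estimate for compound 4 is 19000 nM, range 9000 nM to 40000 nM.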

Compound 4, half-maximal inhibitory concentration: 10300 nM
Compound 4: middle estimate off by 1.8-fold (0.27 log units), on the high side, within the range that was stated.
By their numbers in this assay, from the lowest: compounds 4, 3, 1 and 2 (each within the scatter of the next, the first and the last beyond it).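

Moving the nitrile gives the first step beyond the scatter in this series, a 2.2-fold lower number from compound 2 to compound 4 (0.35 log units; beyond the scatter) in this assay, so 2-cyanophenyl and 3-cyanophenyl are modestly distinguishable on the aromatic nitrogen. The exchange of 4-(hydroxymethyl)phenyl for 2-cyanophenyl gives a 1.6-fold lower number from compound 3 to compound 4 (0.20 log units; within the scatter) and does not separate those two groups. Nothing available here accounts for the difference between the two cyanophenyl groups.

Still open, as far as these compounds go, is how an amine or a carboxylic acid on this aryl ring would read. Also open, from the compounds shown here alone, is whether a methoxy group or a fluorine in place of the nitrile would track the nitrile.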